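The compounds below may be only part of what the source reports. "The series", "measured", "known", "first", "only" and "open" are said of these compounds alone.

Measured compounds:
compound 1, `COc1ccc(/C=C2/S/C(=N/c3ccccc3)N(Cc3ccncc3)C2=O)cc1`: 19100 nM
compound 2, `O=C1/C(=C\c2ccc([N+](=O)[O-])cc2)S/C(=N/c2ccccc2)N1Cc1ccncc1`: 18900 nM
compound 3, `O=C1/C(=C\c2cccc(Cl)c2)S/C(=N/c2ccccc2)N1Cc1ccncc1`: 28900 nM

In a functional assay on HepG2 cells (Homo sapiens) for cytotoxicity, read by MTT assay, with a stated time of 48 h (on this read-out higher numbers stand for weaker inhibition and lower numbers for stronger inhibition), compound 2 gives 18900 nM, and the three numbers do not separate from one another: a 1.0-fold lower number from compound 1 to compound 2 (0.00 log units; within the scatter), and a 1.5-fold higher number from compound 2 to compound 3 (0.18 log units; within the scatter). Compound 4, `O=C1/C(=C\c2ccccn2)S/C(=N/c2ccccc2)N1Cc1ccncc1`, differs from compound 2 in one place: pyridin-2-yl in place of 4-nitrophenyl on a double-bonded chain carbon bound to a double-bonded ring carbon.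

Among the compounds with values here, two measured steps bear on this. The first, a 1.0-fold lower number from compound 1 to compound 2 (0.00 log units; within the scatter), swaps one substituent for another on the same aromatic carbon. The second, a 1.5-fold higher number from compound 2 to compound 3 (0.18 log units; within the scatter), replaces the whole aryl group at the very position where compound 4 also changes. Both steps stay within the scatter, so three different aryl groups at this position have left this assay essentially unmoved. Within the data shown here, there is no measured example of a pyridin-2-yl here, and nothing in these data points to a direction of change beyond the scatter.

Compound 4 is therefore expected to give 21000 nM, with a range from 10000 nM to 45000 nM. For compound 4 the expected step is a 1.1-fold higher number from compound 2 to compound 4 (0.05 log units; within the scatter), which is estimated to remain within the scatter.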

Compound 4, half-maximal inhibitory concentration: 31000 nM
The estimate for compound 4 lay 1.5-fold (0.17 log units) below the measured number, and the stated range covers the measured number.
By their numbers in this assay, from the lowest: compounds 2, 1, 3 and 4 (each within the scatter of the next).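

Pyridin-2-yl is the only one of the four aryl groups here with a hetero atom in its ring, and it too stays within the scatter in this assay (a 1.6-fold higher number from compound 2 to compound 4 (0.21 log units; within the scatter); a 1.6-fold higher number from compound 1 to compound 4 (0.21 log units; within the scatter); a 1.1-fold higher number from compound 3 to compound 4 (0.03 log units; within the scatter)). Even the exchange of 4-nitrophenyl, with 9 heavy atoms, for pyridin-2-yl, with 6, therefore produces no step that can be told apart from the scatter, so all four aryl groups on this double-bonded chain carbon remain inseparable. No measurement shown accounts for these numbers.

On these data alone, it remains open whether something other than an aromatic ring at this position, such as a carboxylic acid, an amine or a longer alkyl chain, would leave the scatter. The compounds also leave open whether changes elsewhere on the shared core would do so.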